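From Acetyl to Thiophen-2-yl on the Oxygen

A few compounds are considered here, and "the series" means these few. Any claim that something is new, unique, unknown or untested is made for them only; others in the source may bear on it.

Three compounds with a shared core differ only in the group on an oxygen on an aromatic ring. In a functional assay on KB cells (Homo sapiens) for cytotoxicity (on this read-out lower numbers stand for stronger inhibition and higher numbers for weaker inhibition), compound 1 (`COc1ccc2c(c1)C(=O)C=CC2=O`) gives 33900 nM, compound 2 (`C=CCOc1ccc2c(c1)C(=O)C=CC2=O`) gives 10200 nM, and compound 3 (`CC(=O)Oc1ccc2c(c1)C(=O)C=CC2=O`) gives 22100 nM. Compound 3 therefore stands with compound 1 at the higher end of these numbers. The gap of a 1.5-fold lower number from compound 1 to compound 3 (0.19 log units; within the scatter) lies within the scatter, while a 2.2-fold higher number from compound 2 to compound 3 (0.34 log units; beyond the scatter) goes modestly beyond it.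

Compound 4 (`O=C1C=CC(=O)c2cc(Oc3cccs3)ccc21`) carries a new change, thiophen-2-yl in place of acetyl on an oxygen on an aromatic ring. Within the data shown here, no measured compound has a ring on this oxygen, so the evidence is indirect. The largest step seen among these swaps is only modest, at a 3.3-fold lower number from compound 1 to compound 2 (0.52 log units; beyond the scatter), and compound 2 holds the lowest number, 10200 nM. A small move towards lower numbers in this assay therefore seems likeliest, though it may not clear the scatter. The expected change is a 1.8-fold lower number from compound 3 to compound 4 (0.27 log units; within the scatter). Compound 4 is estimated at 12000 nM, with an expected range from 4000 nM to 33000 nM.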

Compound 4, half-maximal inhibitory concentration: 18300 nM
The estimate for compound 4 lay 1.5-fold (0.18 log units) below the measured number; measured number inside the range.
By their numbers in this assay, from the lowest: compounds 2, 4, 3 and 1 (each within the scatter of the next, the first and the last beyond it).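

Thiophen-2-yl is the first ring placed on this oxygen, and in this assay the swap from acetyl barely registers (a 1.2-fold lower number from compound 3 to compound 4 (0.08 log units; within the scatter)). Compared with the other two groups, the ring is also within the scatter (a 1.8-fold higher number from compound 2 to compound 4 (0.25 log units; within the scatter) and a 1.9-fold lower number from compound 1 to compound 4 (0.27 log units; within the scatter)), so compound 4 cannot be told apart from any of the three, even though compound 1 and compound 2 differ beyond the scatter. So this position tolerates an aromatic ring of five heavy atoms without any clear change in the number, and no measurement here offers an explanation for that.

As far as these compounds go, it remains open whether a phenyl ring on this oxygen would behave like thiophen-2-yl, which would show whether the sulfur matters. A longer chain ending in an amine or a carboxylic acid is also untested territory in this set.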